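The source may report more compounds than this note shows. Statements on the series, on what has been measured and on what is new or still open speak of the compounds shown alone.

For the measured compounds named here, in a physicochemical assay for solubility, read by HPLC (on this read-out lower numbers stand for lower solubility and higher numbers for higher solubility), compound 2 `O=C(c1ccccc1Cl)N1CCN(c2nc(=O)c3cc(C(F)(F)F)cc([N+](=O)[O-])c3s2)CC1` gives 8.18 ug/mL, which stands within the scatter of compound 1 `O=c1nc(N2CCN(CC3CCCCC3)CC2)sc2c([N+](=O)[O-])cc(C(F)(F)F)cc12` at 9.07 ug/mL; the one measured step is a 1.1-fold lower number from compound 1 to compound 2 (0.04 log units; within the scatter). Compound 3 `CCC(=O)N1CCN(c2nc(=O)c3cc(C(F)(F)F)cc([N+](=O)[O-])c3s2)CC1` differs from compound 2 in that (ethyl in place of 2-chlorophenyl on a carbonyl carbon). Going by the values given here, no measured step touches the carbonyl carbon; the single step, on an amine nitrogen in a ring, lay within the scatter, so no step beyond the scatter is expected in this assay either. Compound 3 is therefore expected to give about 9 ug/mL, between 4 ug/mL and 20 ug/mL. That expectation amounts to a 1.1-fold higher number from compound 2 to compound 3 (0.04 log units; within the scatter).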

Compound 3, solubility: 3.29 ug/mL
For compound 3 the middle estimate is 2.7-fold (0.44 log units) above the measured one; measured number below the stated range.
By their numbers in this assay, from the lowest: compound 3; then compounds 2 and 1 (each within the scatter of the next).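

In this assay, for the compounds shown here, the carbonyl carbon is the first place where a change goes beyond the scatter, with ethyl replacing 2-chlorophenyl: a 2.5-fold lower number from compound 2 to compound 3 (0.40 log units; beyond the scatter). On the amine nitrogen in a ring, propanoyl in place of cyclohexylmethyl also goes beyond the scatter, unlike (2-chlorophenyl)carbonyl there: a 2.8-fold lower number from compound 1 to compound 3 (0.44 log units; beyond the scatter). No available evidence accounts for either step.

Open, from the compounds shown here alone, is whether the number follows the size of the group on the carbonyl carbon, or whether a plain phenyl, a longer chain or an amine there would sit nearer compound 2 or compound 3.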